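This account rests on a few compounds, and the source may have more. Where it says the series, first, only, none or still open, it means among the compounds named here.

Measured in a functional assay, with a stated time of 30 min; a lower number here means that less compound is needed, a higher number that more compound is needed for the effect:
- compound 1 `CCOC(=O)/C=C(/C(=O)OCC)[C@H]1c2c(cc(O)c(O)c2O)C(=O)O[C@@H]1C(=O)OC` gives 4400 nM
- compound 2 `CCOC(=O)/C=C(/C(=O)OCC)[C@H]1c2c(cc(O)c(O)c2O)C(=O)O[C@@H]1C(=O)O` gives 5400 nM
- compound 3 `CCOC(=O)/C(=C/C(=O)O)[C@H]1c2c(cc(O)c(O)c2O)C(=O)O[C@@H]1C(=O)OCC` gives 10800 nM

Compound 3 lies within the scatter of compound 2 and needs more compound than compound 1, beyond the scatter. Next is compound 4 `CCOC(=O)/C=C(/C(=O)OCC)[C@H]1c2c(cc(O)c(O)c2O)C(=O)O[C@@H]1C(=O)OCC`, where the carboxy group of compound 3 becomes ethoxycarbonyl: ethyl in place of hydrogen on an oxygen next to a carbonyl group. Among the compounds with values here, the one measured step of this kind, on a different carbonyl group and involving methyl, is a 1.2-fold higher number from compound 1 to compound 2 (0.09 log units; within the scatter), within the scatter. Compound 1, without a free carboxy group, gives 4400 nM, but compound 2, which has one, gives 5400 nM and goes against any link. A modest move to a lower number is therefore expected, a 1.8-fold lower number from compound 3 to compound 4 (0.26 log units; within the scatter). For compound 4 the estimate is 6000 nM, with an expected range of 2800 nM to 12000 nM.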

Compound 4, half-maximal effective concentration: 2200 nM
Beside the measured number, compound 4's estimate is 2.7-fold (0.44 log units) above it; the measured number lies below the stated range.
By their numbers in this assay, from the lowest: compounds 4, 1, 2 and 3 (each within the scatter of the next, the first and the last beyond it).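

In this assay, ethyl in place of hydrogen on an oxygen next to a carbonyl group gives steps beyond the scatter on two different carbonyl groups: a 4.9-fold lower number from compound 3 to compound 4 (0.69 log units; beyond the scatter) and a 2.5-fold lower number from compound 2 to compound 4 (0.39 log units; beyond the scatter). The earlier step of this kind, involving methyl, stayed within the scatter. Methyl in place of hydrogen on the saturated chain carbon gives a 2.0-fold lower number from compound 1 to compound 4 (0.30 log units; within the scatter), so methoxycarbonyl and ethoxycarbonyl are not separated here.

No evidence bears on the reason for these steps. As far as these compounds go, whether a propyl ester or an amide on either carbonyl group would lower the number further stays open.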